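The source may report more compounds than this note shows. Statements on the series, on what has been measured and on what is new or still open speak of the compounds shown alone.

The study concerns a small set of compounds that share a core and differ only in the groups on the aromatic ring. Compound 1 `Clc1ccc(OCC2=NCCO2)cc1` carries a chloro group; compound 2 `Cc1ccccc1OCC1=NCCO1` carries a methyl group; compound 3 `Cc1cc(OCC2=NCCO2)ccc1Cl` carries both a chloro and a methyl group. Compound 4 `Cc1ccc(OCC2=NCCO2)c(C)c1` carries two methyl groups and has not yet been measured.

In a toxicity assay on the whole organism with Rattus norvegicus as the target, at a dose of 200 mg/kg by the oral route (on this read-out lower numbers stand for a weaker effect and higher numbers for a stronger effect at the one dose given), compound 1 gives 60%. In this assay compound 2 gives 60%, level with compound 1 at the digits given. In this assay compound 3 gives 70%.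

Compound 3 arises from compound 1 by methyl in place of hydrogen on an aromatic carbon, and this change made a step of a number 10 percentage points higher from compound 1 to compound 3 (within the scatter). How the core of compound 2 differs from that of compound 1 is not broken down here.

Compound 4 arises from compound 2 by methyl in place of hydrogen on an aromatic carbon. This is the same kind of change as from compound 1 to compound 3, but the place differs: there the entering methyl sits ortho to a chloro group and meta to a group of 7 heavy atoms, here it sits meta to a methyl group and para to a group of 7 heavy atoms. Since the earlier change stayed within the scatter, the step from compound 2 to compound 4 is expected to be of similar size, a number 5 percentage points higher from compound 2 to compound 4 (within the scatter). Compound 4 is therefore estimated to give 65% in this assay, between 45% and 85%.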

Compound 4, a percentage reported as activity, at one dose (the size of the read-out at that dose, not a potency): 50%
The estimate for compound 4 lay 15 percentage points above the measured number; low and high end bracket the measured number.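

In this assay, methyl in place of hydrogen on an aromatic carbon gave a step of a number 10 percentage points lower from compound 2 to compound 4 (within the scatter), which taken alone is no larger than repeated measurements would be expected to vary. Set beside the earlier step, however, the same change did not carry over unchanged from one core to the other: the same change on two cores in this assay, a number 10 percentage points higher (within the scatter) from compound 1 to compound 3 and a number 10 percentage points lower (within the scatter) from compound 2 to compound 4, 20 percentage points apart, beyond the scatter of two such steps. This shows that, in this series, the step seen on one core cannot simply be transferred to another, but it does not show why the two steps part, since the cores differ and the entering methyl also sits in a different place, in compound 4 meta to a methyl group and para to a group of 7 heavy atoms.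

The compounds shown rest on only one pair of steps, so they leave open whether the gap follows the core, the place of the entering methyl, or both, and whether it would recur on further cores. They also leave open how this toxicity read-out would respond to an amine, a carboxylic acid or a longer chain on the aromatic ring in place of the methyl.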